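Cytotoxicity of glucoside-linked oxindoles on Vero cells

The source may hold more compounds than are shown below. What is called first, only, known or untested is meant among the compounds shown, and "the series" means these compounds.

Measured compounds:
- compound 2 `CCCN1C(=O)/C(=C\C(=O)C[C@@H]2O[C@H](COC(C)=O)[C@@H](OC(C)=O)[C@H](OC(C)=O)[C@H]2OC(C)=O)c2ccccc21`: 125000 nM
- compound 3 `CCCN1C(=O)/C(=C\C(=O)C[C@@H]2O[C@H](COC(C)=O)[C@@H](OC(C)=O)[C@H](OC(C)=O)[C@H]2OC(C)=O)c2cc(Cl)ccc21`: 95600 nM

In an ADME assay on Vero cells (Chlorocebus sabaeus) for cytotoxicity, read by resazurin assay, with a stated time of 72 h (a lower number here means that less compound is tolerated, a higher number that more compound is tolerated), compound 3 gives 95600 nM, the lowest of the two numbers in hand, while compound 2 sits a 1.3-fold lower number from compound 2 to compound 3 (0.12 log units; within the scatter) away, within the scatter. Compound 1 `CC(=O)OC[C@H]1O[C@@H](CC(=O)CC2(O)C(=O)N(Cc3ccc(F)cc3)c3ccc(Cl)cc32)[C@H](OC(C)=O)[C@@H](OC(C)=O)[C@@H]1OC(C)=O` belongs to the same series; in this assay compound 1 gives "not determined" (no result reported).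

Compound 4 `CC(=O)OC[C@H]1O[C@@H](CC(=O)/C=C2\C(=O)N(Cc3ccc(Br)cc3)c3ccc(Cl)cc32)[C@H](OC(C)=O)[C@@H](OC(C)=O)[C@@H]1OC(C)=O` differs from compound 3 by 4-bromophenyl in place of ethyl on a saturated chain carbon bound to an amide-type nitrogen in a ring. Going by the values given here, no measured step covers this change; the only measured step, a 1.3-fold lower number from compound 2 to compound 3 (0.12 log units; within the scatter), concerns a ring substituent and stays within the scatter, so it gives little guidance. Compound 4 is therefore estimated, with wide uncertainty, at 50000 nM (range 15000 nM to 150000 nM), an expected step of a 1.9-fold lower number from compound 3 to compound 4 (0.28 log units; within the scatter).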

Compound 4, half-maximal cytotoxic concentration: 93300 nM
Estimate against measurement, compound 4: 1.9-fold (0.27 log units) below; the measured number falls inside the stated range.
By their numbers in this assay, from the lowest: compounds 4, 3 and 2 (each within the scatter of the next).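

In this assay, putting 4-bromophenyl in place of ethyl on a saturated chain carbon bound to an amide-type nitrogen in a ring gives a 1.0-fold lower number from compound 3 to compound 4 (0.01 log units; within the scatter). This position therefore takes on a whole aromatic ring with no change beyond the scatter, something the earlier step, a chloro on an aromatic carbon, could not show. No measurement here gives a reason for this result. From the compounds shown here alone, whether a longer chain in place of propyl, or an amine or a carboxylic acid in place of the bromine, would move the number stays open.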